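The compounds below may be only part of what the source reports. "The series", "measured", "known", "first", "only" and "open" are said of these compounds alone.

Compound 1 `O=S(=O)(Nc1ccc(Br)c(Cl)c1)c1ccc(-c2cnc(C3CC3)o2)cc1` gives 491 nM
Compound 2 `O=S(=O)(Nc1ccc(F)cc1F)c1ccc(-c2cnc(C3CC3)o2)cc1` gives 356 nM

In a functional assay on cells (leukaemia cell line, Homo sapiens) for inhibition, read by sulforhodamine B assay, with a stated time of 48 h (a higher number here means a weaker inhibitor of growth, a lower number a stronger inhibitor of growth), compound 2 stands level with compound 1 (the gap lies within the scatter), so neither can be ranked above the other. Compound 3 `O=S(=O)(Nc1cc(Cl)ccc1Cl)c1ccc(-c2cnc(C3CC3)o2)cc1` has not yet been measured. It keeps the shared core and swaps one group: 2,5-dichlorophenyl in place of 2,4-difluorophenyl on a sulfonamide nitrogen. Among the compounds with values here, one measured step bears on this, at the same place: a 1.4-fold lower number from compound 1 to compound 2 (0.14 log units; within the scatter) with 2,4-difluorophenyl in place of 4-bromo-3-chlorophenyl. That swap stayed within the scatter. Two values are a thin base, and neither measured compound carries the 2,5-dichlorophenyl group, so the range must stay wide. The expected step is a 1.1-fold higher number from compound 2 to compound 3 (0.05 log units; within the scatter) and nothing beyond the scatter is expected. For compound 3 the estimated value is 400 nM (expected range 170 nM to 950 nM).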

Compound 3, concentration for 50% growth inhibition: 1020 nM
Compound 3: middle estimate off by 2.6-fold (0.41 log units), on the low side, outside the stated range (above it).
By their numbers in this assay, from the lowest: compounds 2 and 1 (each within the scatter of the next); then compound 3.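

At the sulfonamide nitrogen, the choice of halogen-bearing phenyl group can shift the result in this assay beyond the scatter, which the earlier swap at this place did not show: 2,5-dichlorophenyl brings a rise against 2,4-difluorophenyl (a 2.9-fold higher number from compound 2 to compound 3 (0.46 log units; beyond the scatter)) and against 4-bromo-3-chlorophenyl (a 2.1-fold higher number from compound 1 to compound 3 (0.32 log units; beyond the scatter)). Both steps are modest, yet they make compound 3 the weakest growth inhibitor of these three, so having halogens on this phenyl ring does not by itself keep the number level. Nothing measured here explains why this group behaves differently from the other two.

As far as these compounds go, all three groups are halogen-bearing phenyl rings, so the response to a phenyl ring carrying an amine or a methoxy group remains open. From the compounds shown here alone, whether these steps would hold on a different core also remains open.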